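A few compounds are considered here, and "the series" means these few. Any claim that something is new, unique, unknown or untested is made for them only; others in the source may bear on it.

Compound 2, `CC(C)ONC(=N)c1ccc2[nH]c(-c3cccc(-c4ccccc4O)c3O)cc2c1`, is the lower of the two compounds measured in an in vivo ADME assay on the whole organism (strain Sprague-Dawley) for pharmacokinetics, with Rattus norvegicus as the target; on this read-out lower numbers stand for lower oral bioavailability and higher numbers for higher oral bioavailability: in this assay compound 2 gives 10%, while compound 1, `CCONC(=N)c1ccc2[nH]c(-c3cccc(-c4ccccc4O)c3O)cc2c1`, gives 67%. Within the data shown here, the only step so far, a number 57 percentage points lower from compound 1 to compound 2 (beyond the scatter), is large and points downward. Compound 3, `N/C(=N/C(=O)OCC(Cl)(Cl)Cl)c1ccc2[nH]c(-c3cccc(-c4ccccc4O)c3O)cc2c1`, is reached from compound 2 by a group of 11 heavy atoms (4 carbon, 2 nitrogen, 2 oxygen, 3 chlorine; no ring) in place of a group of 7 heavy atoms (4 carbon, 2 nitrogen, 1 oxygen; no ring), on an aromatic carbon. The step from compound 1 to compound 2 bears on this only indirectly, since the methyl that made that step sits inside the group that leaves in compound 3, and nothing is known about the group that enters. With the whole group exchanged, the low reading of compound 2 cannot simply be carried over, nor can the higher one of compound 1. Compound 3 is therefore expected to sit somewhere between the two, with a step of a number 20 percentage points higher from compound 2 to compound 3 (beyond the scatter) upward from compound 2, estimated at 30% in this assay, within a broad range from 5% to 65%.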

Compound 3, oral bioavailability: 14%
For compound 3 the middle estimate is 16 percentage points above the measured one; the range from low to high includes it.
By their numbers in this assay, from the lowest: compounds 2 and 3 (each within the scatter of the next); then compound 1.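

In this assay, putting the group of 11 heavy atoms, with its 3 chlorine atoms, 1 hydrogen-bond donor in place of 2, and 2 double bonds outside aromatic rings, on this aromatic carbon gives a number 4 percentage points higher from compound 2 to compound 3 (within the scatter). Among these compounds, compound 2 and compound 3 therefore cannot be told apart on this read-out, although the two groups differ far more than the single methyl that separates compound 1 from compound 2. The same entering group gives a number 53 percentage points lower from compound 1 to compound 3 (beyond the scatter), so the high reading at this position now belongs to the group of compound 1 alone, while two quite different groups share the low level, and nothing shown explains either reading.

The compounds shown leave open how a straight propyl chain on the oxygen would read, which would help show whether the low reading of compound 2 goes with chain length or with branching. They also leave open whether the entering group needs its chlorine atoms for its reading, a question that a plain ethyl group in place of the trichloroethyl group could address.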